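Hydroxy added to compound 2: expectation for compound 4

The source may report more compounds than this note shows. Statements on the series, on what has been measured and on what is new or still open speak of the compounds shown alone.

Measured in an assay on isolated protein for inhibition of NADPH oxidase 2 (Homo sapiens), read by chemiluminescence, in the presence of a further agent that is not named here; on this read-out higher numbers stand for weaker inhibition and lower numbers for stronger inhibition:
compound 1 `CN1C(=S)N(C2CCCCC2)C(=O)/C1=C\c1ccc(N(C)C)cc1` gives 3580 nM
compound 2 `CN1C(=S)N(C2CCCCC2)C(=O)/C1=C\c1ccc(N(C)CCCO)cc1` gives 2400 nM
compound 3 `CN1C(=S)N(c2ccccc2)C(=O)/C1=C\c1ccc(N(C)CCCO)cc1` gives 2720 nM

Compound 2 holds the lowest of the three numbers, but its steps to the other two sit within the scatter: a 1.5-fold lower number from compound 1 to compound 2 (0.17 log units; within the scatter) and a 1.1-fold higher number from compound 2 to compound 3 (0.05 log units; within the scatter). Compound 4 `CN1C(=S)N(C2CCCCC2)C(=O)/C1=C\c1ccc(N(C)CCCO)cc1O` is the next step from compound 2: hydroxy in place of hydrogen on an aromatic carbon, ortho to a large group and meta to the (3-hydroxypropyl)(methyl)amino group. Neither measured step touches this aromatic ring, and both were within the scatter; no measured change at an aromatic carbon exists in the series. No step beyond the scatter is therefore expected in this assay in either direction. The value estimated for compound 4 is 2400 nM, with a range of 1000 nM to 6000 nM, meaning an expected step of no change at the digits printed from compound 2 to compound 4 (within the scatter).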

Compound 4, half-maximal inhibitory concentration: 3390 nM
Beside the measured number, compound 4's estimate is 1.4-fold (0.15 log units) below it, within the range that was stated.
By their numbers in this assay, from the lowest: compounds 2, 3, 4 and 1 (each within the scatter of the next).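

Hydroxy in place of hydrogen on an aromatic carbon, ortho to a large group, is the first change on this aromatic ring, and in this assay the result is a 1.4-fold higher number from compound 2 to compound 4 (0.15 log units; within the scatter) and no step beyond the scatter. This aromatic carbon therefore carries the added hydroxy with the number held within the scatter of compound 2. No measurement on hand accounts for this outcome.

Going by these compounds, whether methoxy, an amine or a carboxylic acid on this aromatic carbon would give a step beyond the scatter remains open. Also open, on these data alone, is how the same hydroxy reads with phenyl in place of cyclohexyl.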